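The compounds below may be only part of what the source reports. "The series", "measured", "known", "first", "only" and "open" are said of these compounds alone.

Working notes on the series, read in a functional assay on HT-29 cells (Homo sapiens) for inhibition; a higher number here means a weaker inhibitor, a lower number a stronger inhibitor. Compound 1 `COCCOc1cc(/C=C/c2ccc3ccccc3c2)ccc1OC` gives > 5000 nM, which is a limit and not a number. Its standing therefore rests on (the limit of > 5000 nM in this assay, at which 1 of the 3 values shown sits), and it has no exact place among the values. Compound 2 `COCCOc1cc(/C=C\c2ccc3ccccc3c2)ccc1OC` gives 2990 nM. Compound 3 `FC(F)(F)Oc1cccc(/C=C\c2ccc3ccccc3c2)c1` gives 3500 nM, and these two values lie within the scatter of each other.

Among the compounds with values here, the single measured step is an at least 1.6-fold lower number from compound 1 to compound 2 (0.22 log units; that floor lies within the scatter). It comes with the fact that compounds 1 and 2 differ only in the configuration as drawn, so it concerns the double bond alone and offers no measure of a substituent change.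

The next compound is compound 4 `COc1ccc(/C=C/c2ccc3ccccc3c2)cc1[N+](=O)[O-]`, which keeps the double bond as drawn in compound 1. The change is nitro in place of 2-methoxyethoxy on an aromatic carbon, on an aromatic carbon ortho to a methoxy group and meta to a large group. Within the data shown here, no measured step covers this exchange. With compound 1 at > 5000 nM, the starting point is only a limit, so no clear step is expected in this assay beyond the scatter, and a further report of only a limit is more likely than not.

The expected step is a step that the limit leaves unreadable from compound 1 to compound 4. The estimate for compound 4 is 5500 nM, with an expected range of 2000 nM to 12000 nM.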

Compound 4, half-maximal inhibitory concentration: > 5000 nM
Compound 4 was reported as a limit; the forecaster's own chance of this, stated with the estimate: 60%; the middle value does not contradict the limit.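

In this assay compound 4 gives > 5000 nM, which is a limit and not a number. Compound 1 is also reported only as a limit, so no step can be read between compound 1 and compound 4: the limit of > 5000 nM in this assay, at which 2 of the 4 values shown sit.

The compounds shown leave open how far nitro in place of 2-methoxyethoxy on an aromatic carbon moves the value.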